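This account rests on a few compounds, and the source may have more. Where it says the series, first, only, none or still open, it means among the compounds named here.

Compound 1 `NC1CCN(c2nc3c(c(Nc4ccc(C(F)(F)F)cc4)n2)CCN(c2ncccc2C(F)(F)F)CC3)C1`: 3700 nM
Compound 2 `CN(c1nc2c(c(Nc3ccc(C(F)(F)F)cc3)n1)CCN(c1ncccc1C(F)(F)F)CC2)C1CCCNC1`: 3600 nM
Compound 3 `CC(=O)NC1CCN(c2nc3c(c(Nc4ccc(C(F)(F)F)cc4)n2)CCN(c2ncccc2C(F)(F)F)CC3)C1`: 150 nM

These numbers come from a functional assay on HEK293 cells for antagonist activity at transient receptor potential cation channel subfamily V member 1 (Homo sapiens), read by FLIPR and calcium flux; a higher number here means a weaker inhibitor, a lower number a stronger inhibitor. Compound 1 stands at the highest number of the three, with compound 2 nearest, a 1.0-fold lower number from compound 1 to compound 2 (0.01 log units; within the scatter), and compound 3 furthest, a 25-fold lower number from compound 1 to compound 3 (1.39 log units; beyond the scatter). Compound 4 `FC(F)(F)c1ccc(Nc2nc(NC3CCCNC3)nc3c2CCN(c2ncccc2C(F)(F)F)CC3)cc1` differs from compound 1 in one place: (piperidin-3-yl)amino in place of 3-aminopyrrolidin-1-yl on an aromatic carbon. Among the compounds with values here, the step that bears on this is the one from compound 1 to compound 2, which also swapped the five-membered ring for a piperidin-3-yl amine and stayed within the scatter, a 1.0-fold lower number from compound 1 to compound 2 (0.01 log units; within the scatter). The large change a 25-fold lower number from compound 1 to compound 3 (1.39 log units; beyond the scatter) came from an acetyl on the amine, which compound 4 does not carry. A step of a 1.1-fold lower number from compound 1 to compound 4 (0.02 log units; within the scatter) is therefore expected, nothing beyond the scatter. Compound 4 is estimated at 3500 nM, between 1200 nM and 10000 nM.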

Compound 4, half-maximal inhibitory concentration: > 5000 nM
Compound 4: only a limit was reported (the forecaster's own chance of this, stated with the estimate: 10%); at least 1.4-fold (0.15 log units) between middle value and limit.
By their numbers in this assay, from the lowest: compound 3; then compounds 2 and 1 (each within the scatter of the next). At a limit, above all of these: compound 4.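

Compound 4 gave only a limit, > 5000 nM. Hydrogen in place of methyl on the nitrogen on the aromatic ring gives an at least 1.3-fold higher number from compound 2 to compound 4 (0.14 log units; that floor lies within the scatter), and replacing 3-aminopyrrolidin-1-yl gives an at least 1.3-fold higher number from compound 1 to compound 4 (0.13 log units; that floor lies within the scatter): neither floor shows a real loss, but neither change brings the number down. A third amine without an acetyl also stays far from the acetylated compound, with an at least 33-fold higher number from compound 3 to compound 4 (1.52 log units; beyond the scatter).

Still open, as far as these compounds go, is whether an acetyl on the ring nitrogen of the (piperidin-3-yl)amino group would bring a similar drop, and whether a longer acyl chain such as propionyl would do the same on compound 1.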